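The source may hold more compounds than are shown below. What is called first, only, known or untested is meant among the compounds shown, and "the series" means these compounds.

Measured so far in a functional assay on A-375 cells (Homo sapiens) for antiproliferative activity, read by MTT assay, with a stated time of 48 h; a lower number here means a stronger inhibitor of growth, a higher number a weaker inhibitor of growth:
compound 1, `Cc1ccc(C2=NN(C(=S)Nc3ccccc3)C(c3ccc4c(c3)OCCO4)C2)cc1`, gives 6320 nM;
compound 2, `CSc1ccc(C2=NN(C(=S)Nc3ccccc3)C(c3ccc4c(c3)OCCO4)C2)cc1`, gives 159000 nM.

Compound 2 stands at the highest of the two numbers in this assay, the weakest inhibitor of growth of the pair. For the measured compounds named here, the single measured step is a 25-fold higher number from compound 1 to compound 2 (1.40 log units; beyond the scatter), a large loss on exchanging one group for another on the same aromatic carbon.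

Compound 3, `S=C(Nc1ccccc1)N1N=C(c2ccccc2Br)CC1c1ccc2c(c1)OCCO2`, is not yet measured. It differs from compound 2 by 2-bromophenyl in place of 4-(methylsulfanyl)phenyl on a carbon with a double bond to nitrogen. Going by the values given here, no measured step bears on a 2-bromophenyl group in this position. What the data do show is that the methylsulfanyl-bearing compound 2 is far weaker than compound 1, so removing the 4-(methylsulfanyl)phenyl group in compound 3 is expected to recover some of that loss, though how much is uncertain; the step is expected to be a 6.4-fold lower number from compound 2 to compound 3 (0.80 log units; beyond the scatter), a lower number for compound 3. Compound 3 is accordingly expected to give about 25000 nM in this assay, within a range of 5000 nM to 120000 nM.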

Compound 3, concentration for 50% growth inhibition: > 200000 nM
Compound 3 ended at the assay's limit; the forecaster's own chance of this, stated with the estimate: 10%; middle value at least 8.0-fold (0.90 log units) away from the limit.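

Compound 3 reads as a limit in this assay, not as a number: the limit of > 200000 nM in this assay, at which 1 of the 3 values shown sits.

Exchanging 4-methylphenyl for 2-bromophenyl on this carbon gives an at least 31-fold higher number from compound 1 to compound 3 (1.50 log units; beyond the scatter), so a large loss now appears with two different replacements of the 4-methylphenyl group, and that group remains the only one of the three with a value well clear of the limit. Against the 4-(methylsulfanyl)phenyl group, the exchange gives an at least 1.2-fold higher number from compound 2 to compound 3 (0.09 log units; that floor lies within the scatter); that floor lies within the scatter, so no order can be set between these two compounds, and the 2-bromophenyl group shows no readable recovery of growth inhibition.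

Open, as far as these compounds go, is whether the loss follows the bromine itself or its place on the phenyl ring, a question that a 4-bromophenyl group on this carbon would separate. Also open, from the compounds shown here alone, is whether any group here can improve on 4-methylphenyl, for which an unsubstituted phenyl, a 4-methoxyphenyl or a 4-aminophenyl group would give a first reading.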